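This account rests on a few compounds, and the source may have more. Where it says the series, first, only, none or still open, it means among the compounds named here.

Measured compounds:
- compound 1 `O=C(CN(c1nc(Cl)nc2[nH]cnc12)C1CC1)N[C@@H](CO)C(=O)OCc1ccccc1` — 31.9%
- compound 2 `O=C(O)[C@@H]1CCCN1C(=O)CN(c1nc(Cl)nc2[nH]cnc12)C1CC1` — 31.5%
- compound 3 `O=C(CN(c1ncnc2c1ncn2C1CCCCO1)C1CC1)N[C@@H](CCC(=O)OCc1ccccc1)C(=O)OCc1ccccc1` — 32.6%

In a functional assay on the whole organism (Tail, strain ICR) with Mus musculus as the target, in the tail flick test, with a stated time of 30 min, at a dose of 25 umol/kg by the oral route (on this read-out lower numbers stand for a weaker effect and higher numbers for a stronger effect at the one dose given), compound 2 gives 31.5%. Among the three numbers it is the one at the lower end, but compound 1 is nearest to it and compound 3 is furthest, and both of those gaps are within the usual scatter, so the three measured compounds cannot be told apart on this read-out. Compound 1 and compound 3 both carry a benzyl ester and sit in the same range as the free acid of compound 2.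

Compound 4 `O=C(OCc1ccccc1)[C@@H]1CCCN1C(=O)CN(c1nc(Cl)nc2[nH]cnc12)C1CC1` is the next member to be measured in this assay. The change from compound 2 is benzyl in place of hydrogen on an oxygen next to a carbonyl group. Going by the values given here, no step between measured compounds of this kind is available, so only the overall picture can guide the expectation: the benzyl esters already measured give numbers within the scatter of the acid.

The step expected a number 0.5 percentage points higher from compound 2 to compound 4 (within the scatter) is therefore none beyond the scatter, in no particular direction. Compound 4 is estimated at 32%, with a range from 22% to 42%.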

Compound 4, a percentage reported as activity, at one dose (the size of the read-out at that dose, not a potency): 33.2%
Compound 4: the middle estimate sits 1.2 percentage points below what was measured; measured number inside the range.
By their numbers in this assay, from the lowest: compounds 2, 1, 3 and 4 (each within the scatter of the next).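

In this assay, benzyl in place of hydrogen on an oxygen next to a carbonyl group gives a number 1.7 percentage points higher from compound 2 to compound 4 (within the scatter). Going by these compounds alone, this is the first comparison that isolates a single place: carboxy and benzyloxycarbonyl on the same core cannot be told apart on this read-out at the one dose given, whereas the earlier compounds could be set against each other only with several places differing at once. No measurement shown here bears on why this exchange leaves the read-out within the scatter.

As far as these compounds go, it stays open whether another group on this oxygen, such as ethyl or a longer alkyl chain, or an amine-derived amide in place of the carboxy group, would give a step beyond the scatter. A single dose and time point also leave open whether compounds that cannot be told apart here would remain so across a range of doses or at other times.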